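This account rests on a few compounds, and the source may have more. Where it says the series, first, only, none or still open, it means among the compounds named here.

Three compounds built on a shared core have been examined in a functional assay on HepG2 cells (Homo sapiens) for cytotoxicity, read by sulforhodamine B assay, with a stated time of 48 h (on this read-out higher numbers stand for weaker inhibition of growth and lower numbers for stronger inhibition of growth), and for compound 2 (`COc1ccc(N/N=C/c2c(C)nn(-c3ccccc3)c2Oc2ccc(-c3nc4cc(C(N)=O)ccc4[nH]3)cc2)cc1`) the entry reads "not determined" (no result reported). Compound 1 (`Cc1nn(-c2ccccc2)c(Oc2ccc(-c3nc4cc(C(=O)O)ccc4[nH]3)cc2)c1/C=N/NC(N)=S`) gives 46000 nM. Compound 3 (`Cc1nn(-c2ccccc2)c(Oc2ccc(-c3nc4cc(C(N)=O)ccc4[nH]3)cc2)c1/C=N/Nc1ccc([N+](=O)[O-])cc1`) gives 45500 nM, which places compound 3 level with compound 1 within the usual scatter of this assay. Among the compounds with values here, with no result reported for compound 2, only two numbers frame the question.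

Compound 4 (`Cc1nn(-c2ccccc2)c(Oc2ccc(-c3nc4cc(C(N)=O)ccc4[nH]3)cc2)c1/C=N/NC(N)=S`) has yet to be measured in this assay. It departs from compound 3 at one place: a group of 3 heavy atoms (1 carbon, 1 nitrogen, 1 sulfur; no ring) in place of a group of 9 heavy atoms (6 carbon, 1 nitrogen, 2 oxygen; one six-membered aromatic ring of carbon only), on an amine nitrogen. The 4-nitrophenyl group is thus exchanged for a smaller group without a ring.

Within the data shown here, no measured step of this kind is available, so the expectation has little to rest on. Among the measured compounds shown here, with compound 1 at 46000 nM as the only other number, a small step toward stronger inhibition of growth is expected, hardly beyond the scatter. The estimate amounts to a step of a 1.8-fold lower number from compound 3 to compound 4 (0.26 log units; within the scatter), and the uncertainty around it is wide. For compound 4 the expected value is 25000 nM, with an estimated range of 7000 nM to 70000 nM.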

Compound 4, concentration for 50% growth inhibition: 37500 nM
Estimate against measurement, compound 4: 1.5-fold (0.18 log units) below; the measured number falls inside the stated range.
By their numbers in this assay, from the lowest: compounds 4, 3 and 1 (each within the scatter of the next).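

In this assay, within the data shown here, the exchange on the amine nitrogen gives a 1.2-fold lower number from compound 3 to compound 4 (0.08 log units; within the scatter), so replacing the 4-nitrophenyl group with a smaller group without a ring leaves the number within the scatter, which the earlier compounds could not show because they offered no one-place comparison. The result also opens a second place, as amino in place of hydroxy on a carbonyl carbon gives a 1.2-fold lower number from compound 1 to compound 4 (0.09 log units; within the scatter), and this change likewise stays within the scatter. Compound 4 therefore links compound 1 and compound 3 through single changes, neither of which separates the numbers, but no measurement at hand accounts for this.

Compound 2 has no result reported, so its 4-methoxyphenyl group adds nothing to the reading of the amine nitrogen, and these few compounds cannot say whether a plain phenyl or an ethyl group there would stay level as well. From the compounds shown here alone, whether a methyl ester or a primary amine on the core would shift the number beyond the scatter also remains open.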